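The compounds below may be only part of what the source reports. "The series", "measured", "known", "first", "only" and "open" are said of these compounds alone.

Of the compounds shown here, three sharing one core have been tested in an ADME assay on MT4 cells (Homo sapiens) for cytotoxicity, read by MTT assay; a higher number here means that more compound is tolerated, a lower number that less compound is tolerated. Compound 1 `O=C1c2ccccc2C(=O)N1CCOC(=S)N(C(=O)c1ccccc1[N+](=O)[O-])c1ccc(Cl)cc1` gives 21000 nM in this assay. Compound 2 `O=C1c2ccccc2C(=O)N1CCOC(=S)N(C(=O)c1cccc([N+](=O)[O-])c1)c1ccc(Cl)cc1` gives 18000 nM in this assay, and compound 3 `O=C1c2ccccc2C(=O)N1CCOC(=S)N(C(=O)c1ccc(Br)cc1)c1ccc(Br)cc1` gives 73000 nM in this assay. Compound 1 thus stands second highest of the three numbers: its nearest neighbour is compound 2, whose value lies within the scatter of its own, and compound 3 lies furthest away with a higher number that is beyond the scatter. Within the data shown here, compound 3 differs from compound 1 in two places, so only the two values can be set side by side; no single step connects them.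

The step to compound 4 `O=C1c2ccccc2C(=O)N1CCOC(=S)N(C(=O)c1cc(Cl)cc(Cl)c1)c1ccc(Cl)cc1` is 3,5-dichlorophenyl in place of 2-nitrophenyl on a carbonyl carbon. Among the measured compounds shown here, the one step within this set, a 1.2-fold lower number from compound 1 to compound 2 (0.07 log units; within the scatter), only moves the nitro group around the ring and stays within the scatter. For the measured compounds named here, no step here swaps a nitrophenyl for a halogen-bearing phenyl on the carbonyl carbon, so the footing for compound 4 is thin. A modest rise is nevertheless expected, a 1.7-fold higher number from compound 1 to compound 4 (0.22 log units; within the scatter), because compound 3, which carries a bromophenyl on the carbonyl carbon, gives 73000 nM, even though compound 3 also differs on the nitrogen. Compound 4 is estimated at 35000 nM in this assay, within a range from 15000 nM to 80000 nM.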

Compound 4, half-maximal cytotoxic concentration: 32000 nM
Compound 4: the middle estimate sits 1.1-fold (0.04 log units) above what was measured, and the stated range covers the measured number.
By their numbers in this assay, from the lowest: compounds 2, 1 and 4 (each within the scatter of the next); then compound 3.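

In this assay, putting 3,5-dichlorophenyl on the carbonyl carbon in place of a nitrophenyl gives a 1.5-fold higher number from compound 1 to compound 4 (0.18 log units; within the scatter) and a 1.8-fold higher number from compound 2 to compound 4 (0.25 log units; within the scatter) when the starting point is the 3-nitrophenyl compound. The earlier step only moved the nitro group around the ring, whereas these steps remove it altogether and put chlorine atoms on the ring instead, and neither step can be told apart from the scatter. So, for the compounds shown, this position takes a quite different substituted phenyl ring without a measurable shift in tolerated concentration, though no measurement shown here offers an explanation for this.

Compound 3 gives 73000 nM and stands apart from the other three, yet it differs from each of them in two places, so these compounds cannot show which of its two changes goes with that number. Also open, going by these compounds, is what would happen with a phenyl ring carrying an amine or a carboxylic acid on this carbonyl carbon, or with a longer chain there in place of the ring.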